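The source may report more compounds than this note shows. Statements on the series, on what has been measured and on what is new or still open speak of the compounds shown alone.

In a functional assay on A549 cells (Homo sapiens) for antiproliferative activity, read by sulforhodamine B assay, with a stated time of 3 days (a higher number here means a weaker inhibitor of growth, a lower number a stronger inhibitor of growth), compound 3 `COCC(=O)Nc1cccc(Nc2ncc(F)c(Nc3ccc(F)cc3)n2)c1` gives 2050 nM, the lower of the two true numbers available. Compound 1 `O=C(Nc1ccccn1)c1cccc(Nc2ncc(F)c(Nc3ccc(F)cc3)n2)c1` gives 15300 nM. Compound 2 `O=C(Nc1ccc(C(F)(F)F)cc1)c1cccc(Nc2ncc(F)c(Nc3ccc(F)cc3)n2)c1` reads > 10000 nM, which is a limit of the assay and not a number. Compound 4 `O=C(NCCO)c1cccc(Nc2ncc(F)c(Nc3ccc(F)cc3)n2)c1` has (2-hydroxyethyl)carbamoyl in place of the ((methoxymethyl)carbonyl)amino of compound 3: (2-hydroxyethyl)carbamoyl in place of ((methoxymethyl)carbonyl)amino on an aromatic carbon. The most useful guide is a 7.5-fold lower number from compound 1 to compound 3 (0.87 log units; beyond the scatter), which replaced a carbamoyl group with that same ((methoxymethyl)carbonyl)amino group, while a step that the limit leaves unreadable from compound 1 to compound 2 offers no usable size. Compound 4 returns to a carbamoyl group, so part of that change is expected to reverse, with a higher number in this assay. The expected result is a 2.4-fold higher number from compound 3 to compound 4 (0.39 log units; beyond the scatter). For compound 4 the estimated value is 5000 nM, within an expected range of 1500 nM to 18000 nM.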

Compound 4, concentration for 50% growth inhibition: 11900 nM
Compound 4: the middle estimate sits 2.4-fold (0.38 log units) below what was measured, within the range that was stated.
By their numbers in this assay, from the lowest: compound 3; then compounds 4 and 1 (each within the scatter of the next).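

The two side groups hold the same atoms joined differently, yet this assay shows a 5.8-fold higher number from compound 3 to compound 4 (0.76 log units; beyond the scatter) at this aromatic carbon, so the count of atoms alone does not set the number. Among the carbamoyl compounds, the change on the amide-type nitrogen gives a 1.3-fold lower number from compound 1 to compound 4 (0.11 log units; within the scatter) and so separates 2-hydroxyethyl from pyridin-2-yl by no readable amount. The step from compound 2 to compound 4 cannot be read, since compound 2 reads as a limit: the limit of > 10000 nM in this assay, at which 1 of the 4 values shown sits.

Still open, from the compounds shown here alone, is whether ((methoxymethyl)carbonyl)amino keeps its lower number if its methoxy end becomes an amine or a longer chain.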